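A few compounds are considered here, and "the series" means these few. Any claim that something is new, unique, unknown or untested is made for them only; others in the source may bear on it.

Measured so far:
Compound 1, `O=C(CCc1ccccc1-c1cccc(CSCCc2ccccc2)c1)NS(=O)(=O)c1cccs1`: in an assay on isolated protein for binding affinity to prostaglandin E2 receptor EP4 subtype (Homo sapiens) (on this read-out lower numbers stand for stronger inhibition and higher numbers for weaker inhibition), compound 1 gives 1000 nM.
Compound 2, `Cc1cccc(OCCCOc2ccc(-c3ccccc3CCC(=O)NS(=O)(=O)c3cccs3)cc2)c1`: in this assay compound 2 gives 1600 nM.
Compound 3, `Cc1cccc(OCCCOc2ccc(-c3ccccc3CC(C)C(=O)NS(=O)(=O)c3cccs3)cc2)c1`: in this assay compound 3 gives 1100 nM.

Compound 3 stands second highest of the three numbers shown; compound 1 is nearest to it and compound 2 furthest, but all three lie within the scatter of one another, so no ranking among them is claimed.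

Compound 4, `Cc1cccc(OCCCOc2ccc(-c3ccccc3CC(C)(C)C(=O)NS(=O)(=O)c3cccs3)cc2)c1`, is not yet measured. It differs from compound 3 by methyl in place of hydrogen on a saturated chain carbon bound to a carbonyl carbon and two saturated chain carbons, that is, a second methyl at the place where compound 3 already carries one.

Among the measured compounds shown here, the single measured step that bears on this is the first methyl at that place: a 1.5-fold lower number from compound 2 to compound 3 (0.16 log units; within the scatter). For the measured compounds named here, that step stayed within the scatter, and no other pair in the set speaks to a second methyl at the same place. Nothing in these data suggests that the added methyl should move the number beyond the scatter either. The expected step in this assay is therefore a 1.1-fold higher number from compound 3 to compound 4 (0.04 log units; within the scatter), with the direction left open.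

Compound 4 is expected to give 1200 nM, within a range from 500 nM to 3000 nM.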

Compound 4, inhibition constant: 1000 nM
Compound 4: the middle estimate sits 1.2-fold (0.08 log units) above what was measured, within the range that was stated.
By their numbers in this assay, from the lowest: compounds 1, 4, 3 and 2 (each within the scatter of the next).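

In this assay, among the compounds shown here, the second methyl on the saturated chain carbon bound to a carbonyl carbon and two saturated chain carbons gives a 1.1-fold lower number from compound 3 to compound 4 (0.04 log units; within the scatter), whereas the earlier compounds covered only the first methyl at this place, with a 1.5-fold lower number from compound 2 to compound 3 (0.16 log units; within the scatter). Both measured steps at this carbon therefore stay within the scatter, and compound 4, carrying both methyls, gives 1000 nM, while compound 2, carrying neither, gives 1600 nM. No supporting data are available to interpret this result.

Open, from the compounds shown here alone, is whether a group other than methyl at this carbon, such as an ethyl, a hydroxyl, a fluorine or an amine, or a cyclopropane ring formed at it, would take the number beyond the scatter in either direction. Also open is whether the second methyl would give a similar step on the core of compound 1, which gives 1000 nM, since the only methyl steps shown belong to the series of compound 2, compound 3 and compound 4.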